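This account rests on a few compounds, and the source may have more. Where it says the series, first, only, none or still open, it means among the compounds named here.

Measured so far:
compound 1, `COCCNCc1c(-c2nnc(SC(C)C)n2-c2ccccc2)n(C)c2ccccc12`, gives 4.36
compound 2, `COCCNCc1c(-c2nnc(SC(C)C)n2-c2ccccc2)n(C)c2ccc(F)cc12`, gives 4.52
compound 3, `CC(C)Sc1nnc(-c2c(CNCCN3CCCC3)c3cc(F)ccc3n2C)n1-c1ccccc1`, gives 4.99

All three were run in a physicochemical assay for lipophilicity; on this read-out higher numbers stand for higher lipophilicity and lower numbers for lower lipophilicity. Compound 3 stands highest of the three; in this assay compound 3 gives 4.99, and its cores differ from those of compound 2 by pyrrolidin-1-yl in place of methoxy on a saturated chain carbon, two bonds along the chain from an amine nitrogen, a change that brought a number 0.47 log units higher from compound 2 to compound 3 (beyond the scatter). Within the pair sharing the core of compound 2, the change hydrogen in place of fluoro on an aromatic carbon brought a number 0.16 log units lower from compound 2 to compound 1 (within the scatter).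

Compound 4, `CC(C)Sc1nnc(-c2c(CNCCN3CCCC3)c3ccccc3n2C)n1-c1ccccc1`, is not yet measured. It differs from compound 3 by hydrogen in place of fluoro on an aromatic carbon. Going by the values given here, this is the same change as the one from compound 2 to compound 1: the place lines read the same word for word, so the step is taken as the same change, made on the core of compound 3 instead. The step from compound 3 to compound 4 is expected to be a number 0.16 log units lower from compound 3 to compound 4 (within the scatter), resting on the small step of a number 0.16 log units lower from compound 2 to compound 1 (within the scatter). Compound 4 is therefore estimated at 4.83 in this assay, with a range from 4.55 to 5.1.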

Compound 4, partition coefficient: 4.83
Beside the measured number, compound 4's estimate shows no gap at the digits printed; the measured number falls inside the stated range.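

In this assay, hydrogen in place of fluoro on the core of compound 3 brings a number 0.16 log units lower from compound 3 to compound 4 (within the scatter), matching a number 0.16 log units lower from compound 2 to compound 1 (within the scatter), while pyrrolidin-1-yl in place of methoxy brings a number 0.47 log units higher from compound 1 to compound 4 (beyond the scatter), matching a number 0.47 log units higher from compound 2 to compound 3 (beyond the scatter), so among these four compounds each change carries over with no visible gap. Going by these compounds alone, both hydrogen steps lie within the scatter, so their agreement shows only that this change stays small in both settings; the pyrrolidin-1-yl steps lie beyond the scatter and are the firmer case, yet they rest on a single pair of cores and show no general rule for the series. Nothing available here bears on the reason for either step.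

As far as these compounds go, it stays open whether chloro on that aromatic carbon would behave as fluoro does, or whether a morpholin-4-yl group or a longer chain would follow the pyrrolidin-1-yl steps. From the compounds shown here alone, whether either change holds on any other core also remains open.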